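Adding a methoxy group to a pyrazole chalcone series

The source may report more compounds than this note shows. Statements on the series, on what has been measured and on what is new or still open speak of the compounds shown alone.

Measured compounds:
- compound 1, `COc1ccc(-c2cc(/C=C/C(=O)c3ccc(N)cc3)[nH]n2)cc1`, 9250 nM
- compound 2, `COc1ccc(C(=O)/C=C/c2cc(-c3cc(OC)c(OC)c(OC)c3)n[nH]2)cc1OC`, 3030 nM
- compound 3, `COc1ccc(-c2cc(/C=C/C(=O)c3ccc(N)cc3)[nH]n2)cc1OC`, 11500 nM

All three were tested in a functional assay on SK-MEL-5 cells (Homo sapiens) for inhibition, read by sulforhodamine B assay, with a stated time of 48 h; a higher number here means a weaker inhibitor of growth, a lower number a stronger inhibitor of growth. Compound 2 gives 3030 nM, the lowest of the three numbers; the gap from compound 2 to the nearest of the others, compound 1, is beyond the scatter, as is the gap to compound 3. How the core of compound 2 differs from the core of compound 1 is not broken down here.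

One structural change appears twice among these compounds. From compound 1 to compound 3 it is methoxy in place of hydrogen on an aromatic carbon and it made the step of a 1.2-fold higher number from compound 1 to compound 3 (0.09 log units; within the scatter), a change too small to count as a real difference. From compound 2 to the unmeasured compound 4, `COc1cc(C(=O)/C=C/c2cc(-c3cc(OC)c(OC)c(OC)c3)n[nH]2)cc(OC)c1OC`, the change is methoxy in place of hydrogen on an aromatic carbon. The surroundings are not identical: in compound 4 the new group is also meta to a methoxy group, so this is the same kind of change rather than the same one.

Resting on the step from compound 1 to compound 3, compound 4 is expected to stay close to compound 2 in this assay, with an estimated step of a 1.2-fold higher number from compound 2 to compound 4 (0.07 log units; within the scatter). The estimate for compound 4 in this assay is therefore 3600 nM, most likely between 1500 nM and 9000 nM.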

Compound 4, concentration for total growth inhibition: 2940 nM
For compound 4 the middle estimate is 1.2-fold (0.09 log units) above the measured one, within the range that was stated.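

In this assay, putting a methoxy group in place of a hydrogen on an aromatic carbon of compound 2 gives a 1.0-fold lower number from compound 2 to compound 4 (0.01 log units; within the scatter), a step too small to count as a real difference. Set beside the same kind of change on the other core, the two steps agree: the same change on two cores in this assay, a 1.2-fold higher number (0.09 log units; within the scatter) from compound 1 to compound 3 and a 1.0-fold lower number (0.01 log units; within the scatter) from compound 2 to compound 4, 1.3-fold (0.11 log units) apart, within the scatter of two such steps. This shows that on these two cores the change left the number within the scatter both times, so the earlier step was a fair guide here; it does not show that the change would be as quiet on a third core, at another place on the ring, or in any other test, and two steps that both sit within the scatter give no reason for that quietness.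

Still open, on these data alone, is whether a different group at the same place, such as a hydroxyl group, a fluorine atom or a longer chain like ethoxy, would move the number beyond the scatter. Also open, as far as these compounds go, is which part of the structure sets the level of each pair, since compound 1 and compound 2 differ in more than one place and cannot be compared step by step.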